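Adding a Second Fluorine to a Non-Toxic Oxalamide

A few compounds are considered here, and "the series" means these few. Any claim that something is new, unique, unknown or untested is made for them only; others in the source may bear on it.

Compound 1 `Cc1nc(C(NC(=O)C(=O)Nc2ccc(F)cc2)C2CCCCN2)sc1CO` gives > 90000 nM in an ADME assay on TZM-b1 cells (Homo sapiens) for cytotoxicity, read by XTT assay, with a stated time of 3 days; on this read-out lower numbers stand for higher toxicity in this test and higher numbers for lower toxicity in this test.
Compound 2 `Cc1nc(C(NC(=O)C(=O)Nc2ccc(F)cc2)C2CCCCN2)sc1CCO` gives > 88000 nM in this assay.

Both values are limits of this assay, not numbers, so the step that the two limits leave unreadable from compound 1 to compound 2 cannot be sized. Compound 2 therefore stands at a limit in this assay, and compound 1 stands at a limit too (the limit of > 90000 nM in this assay, at which 1 of the 2 values shown sits). Compound 3 `Cc1nc(C(NC(=O)C(=O)Nc2ccc(F)c(F)c2)C2CCCCN2)sc1CCO` differs from compound 2 by fluoro in place of hydrogen on an aromatic carbon. Since no measured step can be read, no size or direction is expected here, only a value again at the limit. Compound 3 is estimated at 90000 nM in this assay, spanning 40000 nM to 200000 nM, so the expected step is a step that the limit leaves unreadable from compound 2 to compound 3.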

Compound 3, half-maximal cytotoxic concentration: > 78200 nM
Compound 3 was reported as a limit; the forecaster's own chance of this, stated with the estimate: 80%; the middle value is on the limit's open side.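

For the compounds shown here, compound 2 and compound 3 both give limits rather than numbers in this assay, so no step between them can be read. On these data alone, whether fluoro in place of hydrogen changes toxicity in this assay stays open, as does the concentration at which either compound would turn toxic.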